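The source may hold more compounds than are shown below. What is called first, only, known or untested is meant among the compounds shown, and "the series" means these compounds.

Working notes on the series. Three measured analogues share one core and differ only in the aryl group on an amide-type nitrogen. Compound 1 `O=C(CSc1nc(Nc2ccccc2)c2ccccc2n1)Nc1ccccc1Br` in a functional assay on MGC-803 cells (Homo sapiens) for inhibition, read by MTT assay, with a stated time of 72 h (on this read-out higher numbers stand for weaker inhibition and lower numbers for stronger inhibition), gives 18600 nM, the highest of the three numbers shown, although within the scatter of both others. Compound 2 `O=C(CSc1nc(Nc2ccccc2)c2ccccc2n1)Nc1cccc(Cl)c1` gives 14300 nM and compound 3 `CCc1cccc(NC(=O)CSc2nc(Nc3ccccc3)c3ccccc3n2)c1` gives 15800 nM. None of the three separate from one another: a 1.3-fold lower number from compound 1 to compound 2 (0.11 log units; within the scatter), a 1.2-fold lower number from compound 1 to compound 3 (0.07 log units; within the scatter), a 1.1-fold higher number from compound 2 to compound 3 (0.04 log units; within the scatter).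

Compound 4 `O=C(CSc1nc(Nc2ccccc2)c2ccccc2n1)Nc1ccc(F)cc1` is not yet measured; relative to compound 1 the change is 4-fluorophenyl in place of 2-bromophenyl on an amide-type nitrogen. The two measured steps that bear on it, a 1.3-fold lower number from compound 1 to compound 2 (0.11 log units; within the scatter) and a 1.2-fold lower number from compound 1 to compound 3 (0.07 log units; within the scatter), each replace the same 2-bromophenyl with a different phenyl group on the amide-type nitrogen, and neither moves beyond the scatter, so no step beyond the scatter is expected in this assay here either. On that basis compound 4 is estimated at 16000 nM, with a range from 7000 nM to 36000 nM. For compound 4 the expected step is therefore a 1.2-fold lower number from compound 1 to compound 4 (0.07 log units; within the scatter), within the scatter.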

Compound 4, half-maximal inhibitory concentration: > 50000 nM
Compound 4 gave a limit, no number; the forecaster's own chance of this, stated with the estimate: 5%; middle value at least 3.1-fold (0.49 log units) from the limit.
By their numbers in this assay, from the lowest: compounds 2, 3 and 1 (each within the scatter of the next). At a limit, above all of these: compound 4.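

In this assay, the aryl group on the amide-type nitrogen proves able to move the read-out beyond the scatter: an at least 2.6-fold higher number from compound 1 to compound 4 (0.42 log units; beyond the scatter), an at least 3.1-fold higher number from compound 3 to compound 4 (0.50 log units; beyond the scatter) and an at least 3.4-fold higher number from compound 2 to compound 4 (0.54 log units; beyond the scatter). Compound 4 stands at a limit of the assay and not at a number: the limit of > 50000 nM in this assay, at which 1 of the 4 values shown sits. The earlier steps among 2-bromophenyl, 3-chlorophenyl and 3-ethylphenyl all stay within the scatter, so they gave no sign that this position could separate compounds, and 4-fluorophenyl is the only group shown that breaks from the other three.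

Open, as far as these compounds go, is whether 4-chlorophenyl or 3-fluorophenyl on the same nitrogen would go with compound 4 or with the other three, which would tell fluoro apart from its place in the name. Also open, from the compounds shown here alone, are the true size of these steps and how an amine or a carboxylic acid on this phenyl ring would read.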